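The source may hold more compounds than are shown below. What is called first, only, known or untested is meant among the compounds shown, and "the series" means these compounds.

Compound 1 (`C=C1[C@H](C)CCC[C@]1(C)CC/C(C)=C/CC1=C(O)C(=O)C=C(N[C@@H](C(=O)O)C(C)C)C1=O`), compound 2 (`CC1=CCC[C@](C)(CC/C(C)=C/CC2=C(O)C(=O)C=C(N[C@@H](C(=O)O)C(C)C)C2=O)[C@@H]1C`), compound 3 (`C=C1[C@H](C)CCC[C@]1(C)CC/C(C)=C/CC1=C(O)C(=O)C=C(N[C@@H](CO)C(=O)O)C1=O`) and compound 4 (`CC1=CCC[C@](C)(CC/C(C)=C/CC2=C(O)C(=O)C=C(NCC(=O)O)C2=O)[C@@H]1C`) share a core but carry different side groups. In an ADME assay on L1210 cells (Mus musculus) for cytotoxicity, with a stated time of 48 h (a higher number here means a weaker inhibitor, a lower number a stronger inhibitor), compound 2 gives 3 ug/mL and compound 1 gives 3.4 ug/mL. The two stand level: a 1.1-fold lower number from compound 1 to compound 2 (0.05 log units; within the scatter) is a change in the carbon ring of the long chain, and it leaves the number within the scatter. Compound 3 gives > 10 ug/mL, which is a limit of the assay and not a number.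

Compound 4 keeps everything in compound 2 except one group: hydrogen in place of isopropyl on a saturated chain carbon bound to an amine nitrogen and a carbonyl carbon. Cut one bond further out, (1-carboxy-2-methylpropyl)amino becomes (carboxymethyl)amino. Among the measured compounds shown here, only one measured step touches this place: an at least 2.9-fold higher number from compound 1 to compound 3 (0.46 log units; beyond the scatter), where the 1-carboxy-2-methylpropyl group gives way to 1-carboxy-2-hydroxyethyl. The isopropyl is lost in that step too, but a different group replaces it, so it is only a loose guide. Even so, a move to a higher number, meaning a weaker inhibitor, is expected in this assay rather than no change. The expected size is a 2.7-fold higher number from compound 2 to compound 4 (0.43 log units; beyond the scatter). Compound 4 is estimated at 8 ug/mL, with an expected range of 3.5 ug/mL to 20 ug/mL.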

Compound 4, half-maximal inhibitory concentration: 3.5 ug/mL
For compound 4 the middle estimate is 2.3-fold (0.36 log units) above the measured one; the measured number falls inside the stated range.
By their numbers in this assay, from the lowest: compounds 2, 1 and 4 (each within the scatter of the next). At a limit, above all of these: compound 3.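

Taking the isopropyl away altogether, leaving only hydrogen on a saturated chain carbon bound to an amine nitrogen and a carbonyl carbon, changes nothing that this assay can resolve: a 1.2-fold higher number from compound 2 to compound 4 (0.07 log units; within the scatter). The isopropyl is therefore not needed to hold the number at this level on the core of compound 2, and the smaller (carboxymethyl)amino group serves as well here as (1-carboxy-2-methylpropyl)amino. Among the compounds shown here, the only earlier step at this place, an at least 2.9-fold higher number from compound 1 to compound 3 (0.46 log units; beyond the scatter), also lost the isopropyl, so the new result shows that this loss alone does not bring such a move, at least with the carbon ring of compound 2.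

As far as these compounds go, compound 3 is known only as a limit, so the distance between it and the other compounds stays open: the limit of > 10 ug/mL in this assay, at which 1 of the 4 values shown sits. Also open, from the compounds shown here alone, is whether a longer chain, a phenyl ring or an amine at this place would leave the number where it stands, and whether the hydroxyl of 1-carboxy-2-hydroxyethyl would have the same standing with the carbon ring of compound 2.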